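The compounds below may be only part of what the source reports. "The series", "measured", "known", "first", "only" and "open" are said of these compounds alone.

Series notes, cytotoxicity read-out.

Compound 1 `CCOc1ccc2oc(/C=C/[S+](C)[O-])cc(=O)c2c1` gives 1500 nM in a functional assay on A549 cells (Homo sapiens) for cytotoxicity, with a stated time of 48 h; on this read-out lower numbers stand for stronger inhibition and higher numbers for weaker inhibition. Compound 2 `CCCCCOc1ccc2oc(/C=C/[S+](C)[O-])cc(=O)c2c1` gives 1600 nM in this assay, and compound 3 `C[S+]([O-])/C=C/c1oc2ccccc2c(=O)c1Cc1ccccc1` gives 1300 nM. Among the measured compounds shown here, the only single-point step among the measured members, a 1.1-fold higher number from compound 1 to compound 2 (0.03 log units; within the scatter), describes propyl in place of hydrogen on a saturated chain carbon, two bonds along the chain from an oxygen on an aromatic ring. Compound 2 thus carries the highest of the three numbers, but its gap to compound 1 and to compound 3 is within the scatter, so no order among the three can be read.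

The next member, compound 4 `CC(C)C(=O)Oc1ccc2oc(/C=C/[S+](C)[O-])cc(=O)c2c1`, differs from compound 2 as follows: isopropylcarbonyl in place of pentyl on an oxygen on an aromatic ring. Cut one bond further out this reads pentyloxy to (isopropylcarbonyl)oxy. For the measured compounds named here, none of the measured steps covers an oxygen on an aromatic ring changing its substituent from a carbon chain to a carbonyl-bearing group; the one step that exists, the chain lengthening from compound 1 to compound 2, was within the scatter. Nothing measured here points to a direction for the new change, so the expectation is a step of no more than the scatter, a 1.1-fold lower number from compound 2 to compound 4 (0.03 log units; within the scatter), with a wide allowance. Compound 4 is accordingly expected to give 1500 nM, estimated to lie between 600 nM and 4000 nM.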

Compound 4, half-maximal inhibitory concentration: 2400 nM
For compound 4 the middle estimate is 1.6-fold (0.20 log units) below the measured one; low and high end bracket the measured number.
By their numbers in this assay, from the lowest: compounds 3, 1, 2 and 4 (each within the scatter of the next).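

In this assay, the substituent on the oxygen on an aromatic ring can change from a plain carbon chain to a carbonyl-bearing group without a readable shift: isopropylcarbonyl in place of pentyl gives a 1.5-fold higher number from compound 2 to compound 4 (0.18 log units; within the scatter) and isopropylcarbonyl in place of ethyl gives a 1.6-fold higher number from compound 1 to compound 4 (0.20 log units; within the scatter) as the matching step from the shorter chain. The earlier compounds shown here covered only a lengthening of the chain at this oxygen, whereas these two steps show that the read-out also stays within the scatter when a carbonyl enters at the same place, with the heavy-atom count unchanged from pentyl. No measurement on hand bears on this result beyond the cytotoxicity numbers themselves.

Going by these compounds, whether an amine, a carboxylic acid or a much longer chain on this oxygen would give a step beyond the scatter remains open. With each of the four compounds within the scatter of the next, the numbers shown give no order at this position, and what kind of group at this oxygen would separate from the others is still unknown.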